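The source may hold more compounds than are shown below. What is called first, only, known or untested is meant among the compounds shown, and "the series" means these compounds.

Three measured compounds frame the question. Compound 1 `O=[N+]([O-])c1ccc(N2CCNCC2)cc1NCCOc1ccc(Cl)cc1` in an assay on HEK293 cells for displacement of a labelled ligand from 5-hydroxytryptamine receptor 6 (Homo sapiens) (on this read-out higher numbers stand for weaker inhibition and lower numbers for stronger inhibition), gives 290 nM. Compound 2 `CN1CCN(c2ccc(C#N)c(NCc3ccco3)c2)CC1`, which carries a nitrile in place of the nitro group and a different side chain, in this assay gives 1370 nM. Compound 3 `COc1ccc(OCCNc2cc(N3CCN(C)CC3)ccc2[N+](=O)[O-])cc1` in this assay gives 245 nM, the lowest number of the three; its gap to compound 1 lies within the scatter of repeated runs, so the two cannot be ranked, whereas its gap to compound 2 lies beyond the scatter.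

Compound 4 `CN1CCN(c2ccc([N+](=O)[O-])c(NCCOc3ccc(C(C)(C)C)cc3)c2)CC1` keeps the shared core of compound 3 and differs from it in one place: tert-butyl in place of methoxy on an aromatic carbon. For the measured compounds named here, no pair of measured compounds shows this change, so there is nothing here that says whether swapping these two groups moves the number. The two measured compounds with a nitro group and an aryloxyethyl side chain, compound 1 and compound 3, sit close together, which suggests that a change at the far end of that side chain may matter little.

On that basis the step from compound 3 to compound 4 in this assay is expected to be small, a 1.1-fold higher number from compound 3 to compound 4 (0.03 log units; within the scatter), and not beyond the scatter. For compound 4 in this assay the expected value is 260 nM, with a likely range from 90 nM to 800 nM.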

Compound 4, inhibition constant: 80 nM
Estimate against measurement, compound 4: 3.3-fold (0.51 log units) above; the measured number lies below the stated range.
By their numbers in this assay, from the lowest: compound 4; then compounds 3 and 1 (each within the scatter of the next); then compound 2.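

In this assay, the far end of the aryloxyethyl side chain proves to be a position that can move the number: tert-butyl in place of methoxy, on an aromatic carbon para to a large group, gives a 3.1-fold lower number from compound 3 to compound 4 (0.49 log units; beyond the scatter), which means stronger inhibition. This is the only pair shown that differs in one place, and the other steps cannot be read, so the closeness of compound 1 and compound 3 could not have shown what this position does on its own. The swap replaces a group of 2 heavy atoms, one of them oxygen and counted as a hydrogen-bond acceptor, with a group of 4 carbon atoms and no acceptor, but no measurement here connects either difference to the gain, and no evidence explains it.

A single step cannot show whether heavy-atom count or the loss of the oxygen matters more; an isopropyl, ethyl or trifluoromethyl group on the same carbon would help separate the two. Going by these compounds, it also remains open whether tert-butyl gives a similar step on the core of compound 1, which has no methyl group on the piperazine nitrogen.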